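The compounds below may be only part of what the source reports. "The series", "measured", "known", "first", "only" and "open" are said of these compounds alone.

Three compounds have values in a physicochemical assay for lipophilicity (a higher number here means a more lipophilic compound, a lower number a more polar compound), as follows:
- compound 1 `CC(C)(C)OC(=O)c1ccc(NC(=O)c2cccc(S(N)(=O)=O)c2)cc1` gives 1.54
- compound 2 `COc1cc(NC(=O)c2cccc(S(N)(=O)=O)c2)cc(OC)c1OC` gives 0.79
- compound 3 `COc1cccc(CNC(=O)c2ccc(Cl)c(S(N)(=O)=O)c2)c1` gives 1.34

Compound 1 and compound 3 lie within the scatter of each other, so neither can be ranked above the other. Compound 2 lies lower than compound 1, and that gap goes beyond the scatter.

Compound 4 `CC(C)(C)OC(=O)c1ccc(NC(=O)c2ccc(Cl)c(S(N)(=O)=O)c2)cc1` has not yet been measured. It differs from compound 1 in one place chloro in place of hydrogen on an aromatic carbon with chloro in place of hydrogen on an aromatic carbon, ortho to a sulfamoyl group and para to a large group. Going by the values given here, no pair of measured compounds shows this change alone, so the expectation has no direct precedent in these data. A moderate upward step in this assay is expected, somewhat beyond the scatter. The estimated step is a number 0.46 log units higher from compound 1 to compound 4 (beyond the scatter) in this account. For compound 4 the expected value is 2 with an estimated range of 1.6 to 2.4 as its likely span.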

Compound 4, partition coefficient: 1.83
For compound 4 the middle estimate is 0.17 log units above the measured one; measured number inside the range.
By their numbers in this assay, from the lowest: compound 2; then compounds 3, 1 and 4 (each within the scatter of the next, the first and the last beyond it).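

In this assay, chloro in place of hydrogen on an aromatic carbon, ortho to a sulfamoyl group and para to a large group, gives a number 0.29 log units higher from compound 1 to compound 4 (within the scatter). Going by these compounds alone, this is the first pair here that differs in one place, and it shows that at this position, on the core of compound 1, the change gives a step that cannot be told apart from the usual scatter of repeated measurements. Nothing available here bears on why the step has this size.

The compounds shown leave open whether an amine or a carboxylic acid at this same position would move the number beyond the scatter. They also leave open whether chloro in place of hydrogen gives a similar step on a different core, such as that of compound 2.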